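This account rests on a few compounds, and the source may have more. Where it says the series, first, only, none or still open, it means among the compounds named here.

The compounds were compared in an assay on cells for inhibition of HSP60/HSP10 (Homo sapiens), with a stated time of 60 min; a lower number here means a stronger inhibitor, a higher number a weaker inhibitor. The measured ones are:

Compound 1, `O=S(=O)(Nc1ccc(-c2nc3ccccc3o2)cc1)c1ccccc1O`, gives > 100000 nM in this assay. That value is a limit of the assay, not a number.
Compound 2, `Cc1cccc(S(=O)(=O)Nc2ccc3oc(-c4ccccc4)nc3c2)c1`, gives > 100000 nM in this assay. That value too is a limit of the assay, not a number.
Compound 3, `O=S(=O)(Nc1ccc(-c2nc3ccccc3o2)cc1)c1cccc(O)c1`, gives 62000 nM in this assay.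

Compound 2 therefore stands at the limit, and it is not alone there, as the limit of > 100000 nM in this assay, at which 2 of the 3 values shown sit, shows. For the measured compounds named here, the only measured step, an at least 1.6-fold lower number from compound 1 to compound 3 (0.20 log units; that floor lies within the scatter), lies within the scatter and concerns hydroxyphenyl groups only.

The unmeasured compound 4, `O=S(=O)(Nc1ccc2oc(-c3ccccc3)nc2c1)c1ccc(Cl)cc1`, differs from compound 2 by 4-chlorophenyl in place of 3-methylphenyl on a sulfonyl sulfur. No measured step involves a 4-chlorophenyl or a 3-methylphenyl group, so nothing among these compounds points to a step beyond the scatter in this assay in either direction. Compound 4 is therefore expected to remain near the limit. The step of a number no higher from compound 2 to compound 4 (the limit leaves the size open) is expected to be small. The estimate for compound 4 in this assay is 100000 nM, with a range from 40000 nM to 300000 nM.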

Compound 4, half-maximal inhibitory concentration: > 100000 nM
Compound 4: a limit, no number (the forecaster's own chance of this, stated with the estimate: 65%); the middle value sits exactly at the limit.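

In this assay compound 4 gives > 100000 nM as a limit of the assay, not a number. Compound 2 also stands at a limit, so no step between compound 2 and compound 4 can be read: the limit of > 100000 nM in this assay, at which 3 of the 4 values shown sit.

Whether 4-chlorophenyl and 3-methylphenyl on a sulfonyl sulfur differ at all in this assay stays open among the compounds shown.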